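The source may hold more compounds than are shown below. What is called first, only, known or untested is meant among the compounds shown, and "the series" means these compounds.

Measured compounds in a functional assay on Jurkat cells (Homo sapiens) for activation, with a stated time of 24 h; a lower number here means that less compound is needed, a higher number that more compound is needed for the effect:

compound 1 `Oc1ccccc1CNc1ccc(-c2ccc(F)cc2)cc1`: 3860 nM
compound 2 `N#Cc1ccc(-c2ccc(NCc3ccccc3O)cc2)cc1`: "not active" (no number reported)
compound 3 `Oc1ccccc1CNc1ccc(-c2ccc(OC(F)(F)F)cc2)cc1`: "not active" (no number reported)

The three measured compounds share one core and differ only in the group on the outer ring. Going by the values given here, compound 1 is the only one with a number; in this assay compound 1 gives 3860 nM. For compound 2 this assay reports "not active" (no number reported), no number, only that it is not active. Compound 3 stands in the same place: in this assay compound 3 gives "not active" (no number reported), no number, only that it is not active, and one further measured compound, compound 2, stands there with it.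

Compound 4 `CC(C)Oc1ccc(-c2ccc(NCc3ccccc3O)cc2)cc1` is the next compound and is not yet measured. It differs from compound 3 by isopropyl in place of trifluoromethyl on an oxygen on an aromatic ring. Among the compounds with values here, no pair of measured compounds differs in one place, so no step of known size exists in this assay from which the effect of this change could be read. Within the data shown here, what the measured compounds show is only that one group on the outer ring gives a weak number, compound 1 with 3860 nM, and two others give none. On that basis a weak result is expected for compound 4, with a substantial chance that this assay again reports no number.

Compound 4 is expected to give about 8000 nM in this assay, estimated within 2000 nM to 30000 nM.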

Compound 4, half-maximal effective concentration: 5940 nM
Compound 4: middle estimate off by 1.3-fold (0.13 log units), on the high side; the measured number falls inside the stated range.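

Isopropoxy in place of fluoro on an aromatic carbon gives in this assay a 1.5-fold higher number from compound 1 to compound 4 (0.19 log units; within the scatter), so the two groups cannot be told apart at this position, and a single group no longer stands alone with a number. An oxygen on the aromatic ring does not by itself remove the number, since with trifluoromethyl on that oxygen compound 3 gives "not active" (no number reported) while with isopropyl compound 4 gives 5940 nM, and in this pair the group on the oxygen separates a reported number from none. Nothing at hand accounts for this difference between trifluoromethoxy and isopropoxy.

From the compounds shown here alone, it remains open whether any group at this position moves the number in this assay beyond the scatter of the two values now known. An amine, a carboxylic acid or a longer alkoxy chain on the outer ring would test this, and would show whether a number is kept with groups unlike fluoro and isopropoxy.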